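The compounds below may be only part of what the source reports. "The series", "measured", "known", "first", "only" and "open" are said of these compounds alone.

Compound 1 `COc1cc(Oc2cccc(Nc3ccccc3)c2)cc(OC)c1CNCc1ccc(Cl)cc1` gives 3740 nM
Compound 2 `COc1ccc(CCCNCc2c(OC)cc(Oc3cccc(Nc4ccccc4)c3)cc2OC)cc1` gives 2540 nM

Both numbers come from a functional assay on DLD-1 cells (Homo sapiens) for inhibition, read by MTT assay, with a stated time of 72 h; a higher number here means a weaker inhibitor, a lower number a stronger inhibitor. Among the measured compounds shown here, of the two measured compounds, compound 2 stands at a number that differs from compound 1 only within the scatter, as the single measured step shows: a 1.5-fold lower number from compound 1 to compound 2 (0.17 log units; within the scatter). Compound 3 `COc1cc(Oc2cccc(Nc3ccccc3)c2)cc(OC)c1CNCc1ccc(O)cc1` has not yet been measured. It differs from compound 2 in one place: 4-hydroxyphenyl in place of 2-(4-methoxyphenyl)ethyl on a saturated chain carbon bound to an amine nitrogen. For the measured compounds named here, the only measured step that bears on this change also swapped the group at the same place on the shared core, and it stayed within the scatter. Going by the values given here, two different groups at this position thus gave about the same number, so nothing among the measured compounds points to a step beyond the scatter in this assay for compound 3. A number close to compound 2 is therefore expected, with the move from compound 2 amounting to a 1.2-fold higher number from compound 2 to compound 3 (0.07 log units; within the scatter). For compound 3 the estimate is 3000 nM, with a range from 1400 nM to 6500 nM.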

Compound 3, half-maximal inhibitory concentration: 2690 nM
The estimate for compound 3 lay 1.1-fold (0.05 log units) above the measured number, and the stated range covers the measured number.
By their numbers in this assay, from the lowest: compounds 2, 3 and 1 (each within the scatter of the next).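

Swapping the 3-(4-methoxyphenyl)propyl group for 4-hydroxybenzyl gives a 1.1-fold higher number from compound 2 to compound 3 (0.02 log units; within the scatter) in this assay, so a third group on this amine nitrogen, now one with a hydrogen-bond donor, still shows no step beyond the scatter. The closer comparison is hydroxy in place of chloro on an aromatic carbon, which gives a 1.4-fold lower number from compound 1 to compound 3 (0.14 log units; within the scatter) with the rest of the molecule unchanged, so this single swap at the ring's outer substituent also stays within the scatter. No data here explain why these groups give such similar numbers.

All three compounds keep a six-membered aromatic ring in this group. As far as these compounds go, a plain alkyl chain without a ring, or a carboxylic acid or an amine on that ring, therefore remains open.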